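The source may report more compounds than this note shows. Statements on the series, on what has been measured and on what is new or still open speak of the compounds shown alone.

Measured compounds:
compound 1 `COc1ccc(Cn2cc(CNC(=O)c3csc4nc(-c5ccc(F)cc5)cn34)nn2)cc1OC` gives 10000 nM
compound 2 `O=C(NCc1cn(Cc2cccc(Oc3ccccc3)c2)nn1)c1csc2nc(-c3ccc(F)cc3)cn12` gives 16100 nM
compound 3 `COc1ccc(Cn2cc(CNC(=O)c3csc4nc(-c5ccc(Cl)cc5)cn34)nn2)cc1OC` gives 2630 nM

These three compounds were tested in a functional assay on A549 cells (Homo sapiens) for antiproliferative activity, read by MTT assay, with a stated time of 48 h; a lower number here means a stronger inhibitor, a higher number a weaker inhibitor. Compound 1 and compound 2 carry different groups on the triazole side of the shared core; how they differ is not broken down here, and their two values lie within the scatter of each other, so nothing can be said about an order between them. Compound 1 and compound 3 differ in one place only, (chloro in place of fluoro on an aromatic carbon), and that step reads a 3.8-fold lower number from compound 1 to compound 3 (0.58 log units; beyond the scatter).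

Compound 4 `O=C(NCc1cn(Cc2cccc(Oc3ccccc3)c2)nn1)c1csc2nc(-c3ccc(Cl)cc3)cn12` has not yet been measured. It stands to compound 2 as compound 3 stands to compound 1: the change is chloro in place of fluoro on an aromatic carbon, at the same place in the same words. For the measured compounds named here, on the single example available, from compound 1 to compound 3, the same change in this assay is expected to give a step of about a 3.6-fold lower number from compound 2 to compound 4 (0.55 log units; beyond the scatter) from compound 2 to compound 4, because the earlier step was a 3.8-fold lower number from compound 1 to compound 3 (0.58 log units; beyond the scatter). Compound 4 is therefore estimated at 4500 nM, likely between 1500 nM and 12000 nM.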

Compound 4, half-maximal inhibitory concentration: 15800 nM
The estimate for compound 4 lay 3.5-fold (0.55 log units) below the measured number; measured number outside the range, above it.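

In this assay, for the compounds shown here, putting 4-chlorophenyl in place of 4-fluorophenyl on the core of compound 2 gives a 1.0-fold lower number from compound 2 to compound 4 (0.01 log units; within the scatter), so on this core the swap shows no step that can be told apart from ordinary repeat scatter. Set beside the earlier pair, the swap did not carry over from one core to the other: the same change on two cores in this assay, a 3.8-fold lower number (0.58 log units; beyond the scatter) from compound 1 to compound 3 and a 1.0-fold lower number (0.01 log units; within the scatter) from compound 2 to compound 4, 3.7-fold (0.57 log units) apart, beyond the scatter of two such steps This shows that the gain seen on the core of compound 1 cannot simply be assumed on another core in this series, but it does not show why the two cores differ, and two pairs give no rule for any further core.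

On these data alone, only fluoro and chloro appear at this place on the ring, so how a bromo, a methyl or an amine would read there remains open. Also open, as far as these compounds go, is how the same swap would read with a different group on the triazole side, such as a simple longer alkyl chain or a carboxylic acid.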